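A few compounds are considered here, and "the series" means these few. Any claim that something is new, unique, unknown or untested is made for them only; others in the source may bear on it.

Compound 1 `COc1cc2ncnc(NNC(=S)NC(=O)c3ccc(C(F)(F)F)cc3)c2cc1OC`, compound 3 `COc1cc2ncnc(NNC(=S)NC(=O)c3cccc(Cl)c3)c2cc1OC` and compound 2 `Cc1ccc(C(=O)NC(=S)NNc2ncnc3ccccc23)cc1` have been measured. In a functional assay on MCF7 cells (Homo sapiens) for cytotoxicity, read by MTT assay, with a stated time of 72 h (a lower number here means a stronger inhibitor, a higher number a weaker inhibitor), compound 1 gives 16800 nM, compound 3 gives 11500 nM and compound 2 gives 7820 nM. For the measured compounds named here, the single step between direct neighbours, a 1.5-fold lower number from compound 1 to compound 3 (0.16 log units; within the scatter), is a swap of the aryl group on the carbonyl carbon. Compound 2 stands within the scatter of compound 3 and beyond the scatter below compound 1. Compound 4 `O=C(NC(=S)NNc1ncnc2ccccc12)c1ccc(F)cc1` differs from compound 2 by fluoro in place of methyl on an aromatic carbon, again a change of the aryl group attached to the carbonyl. Going by the values given here, the only step that bears on it, from compound 1 to compound 3, stayed within the scatter, so in this assay no step beyond the scatter is expected, a 1.1-fold higher number from compound 2 to compound 4 (0.04 log units; within the scatter). Compound 4 is therefore estimated at 8500 nM, within 3800 nM to 19000 nM.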

Compound 4, half-maximal inhibitory concentration: 4590 nM
Compound 4: middle estimate off by 1.9-fold (0.27 log units), on the high side, within the range that was stated.
By their numbers in this assay, from the lowest: compounds 4, 2, 3 and 1 (each within the scatter of the next, the first and the last beyond it).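

In this assay, the swap of 4-methylphenyl to 4-fluorophenyl gives a 1.7-fold lower number from compound 2 to compound 4 (0.23 log units; within the scatter), so the position para to the large group takes either methyl or fluoro without a step beyond the scatter. For the compounds shown here, the earlier aryl step was seen only on the core of compound 1; this one extends the same reading to the core of compound 2. No supporting measurement bears on this result.

As far as these compounds go, whether an amine or a carboxylic acid at this position would step beyond the scatter remains open. So does whether the methyl-to-fluoro swap reads the same on the core of compound 1.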